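The source may report more compounds than this note shows. Statements on the series, on what has been measured and on what is new or still open speak of the compounds shown alone.

Three members of the series are already measured in an assay on COS-7 cells for inhibition of sodium/nucleoside cotransporter 2 (Homo sapiens), read by scintillation counting; on this read-out higher numbers stand for weaker inhibition and lower numbers for stronger inhibition. Compound 1 `Nc1ncnc2c1nc(NCc1ccc(-c3ccccc3)c(O)c1)n2[C@@H]1O[C@H](CO)[C@@H](O)[C@H]1O` gives 1200 nM. Compound 2 `COc1cc(CNc2nc3c(N)ncnc3n2[C@@H]2O[C@H](CO)[C@@H](O)[C@H]2O)ccc1-c1ccccc1` gives 1300 nM in this assay, and compound 3 `CCOc1cc(CNc2nc3c(N)ncnc3n2[C@@H]2O[C@H](CO)[C@@H](O)[C@H]2O)ccc1-c1ccccc1` gives 2300 nM. Compound 1 holds the lowest of the three numbers, but the step of a 1.1-fold higher number from compound 1 to compound 2 (0.03 log units; within the scatter) and the step of a 1.9-fold higher number from compound 1 to compound 3 (0.28 log units; within the scatter) both lie within the scatter, so no order among the three can be read from these numbers. The step of a 1.8-fold higher number from compound 2 to compound 3 (0.25 log units; within the scatter) is likewise within the scatter.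

Compound 4 `CC(C)Oc1cc(CNc2nc3c(N)ncnc3n2[C@@H]2O[C@H](CO)[C@@H](O)[C@H]2O)ccc1-c1ccccc1` is not yet measured in this assay. It differs from compound 1 by isopropyl in place of hydrogen on an oxygen on an aromatic ring. The measured steps that bear on this change are those that place an alkyl group on the same oxygen: a 1.1-fold higher number from compound 1 to compound 2 (0.03 log units; within the scatter) and a 1.9-fold higher number from compound 1 to compound 3 (0.28 log units; within the scatter). Neither exceeds the scatter, although the ethyl step is the larger of the two. Compound 4 continues this exchange with isopropyl, so a step of similar or somewhat greater size is expected, towards a higher number, with no strong reason from the data to expect a fall; the expected step is a 2.3-fold higher number from compound 1 to compound 4 (0.37 log units; beyond the scatter). Compound 4 is therefore estimated at 2800 nM, with a range from 1200 nM to 6500 nM.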

Compound 4, half-maximal inhibitory concentration: 10400 nM
Compound 4: the middle estimate sits 3.7-fold (0.57 log units) below what was measured; the whole stated range lies below it.
By their numbers in this assay, from the lowest: compounds 1, 2 and 3 (each within the scatter of the next); then compound 4.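

Among these compounds, compounds with hydrogen, methyl or ethyl on this oxygen lie within the scatter of one another in this assay, whereas isopropyl is the first group here to move the number beyond it, with an 8.7-fold higher number from compound 1 to compound 4 (0.94 log units; beyond the scatter) and, against the methyl ether, an 8.0-fold higher number from compound 2 to compound 4 (0.90 log units; beyond the scatter) as the result. The ethyl and isopropyl ethers differ only by a methyl on the saturated chain carbon bound to the oxygen, and that single addition gives a 4.5-fold higher number from compound 3 to compound 4 (0.66 log units; beyond the scatter), so the change at this position is not spread evenly along the series but appears at this last step. No measurement among the data shown explains this rise.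

From the compounds shown here alone, whether the rise follows branching at that carbon or simply the number of carbons on the oxygen remains open, and a straight propyl group on the same oxygen would separate the two readings. Going by these compounds, how far the position accepts larger or different groups also remains open, for instance a tert-butyl or cyclopropyl group, or an ethyl chain ending in an amine or a carboxylic acid.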